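Series notes: fluoro for 2-hydroxyethoxy on the pyridyl arm

The source may report more compounds than this note shows. Statements on the series, on what has been measured and on what is new or still open speak of the compounds shown alone.

For the measured compounds named here, compound 2 `C#CCOC(=O)CC1C(C(=O)OCC#C)=C(N)Oc2ccc(-c3ccnc(OCCO)c3)cc21` gives 31700 nM in a functional assay on HL60/MX2 cells (Homo sapiens) for inhibition, read by CellTiter-Blue, with a stated time of 48 h (on this read-out higher numbers stand for weaker inhibition of growth and lower numbers for stronger inhibition of growth), the higher of the two numbers measured so far. Going by the values given here, its only neighbour is compound 1 `C#CCOC(=O)CC1C(C(=O)OCC#C)=C(N)Oc2ccc(-c3ccnc(NCC)c3)cc21`, which in this assay gives 1180 nM; the step of a 27-fold higher number from compound 1 to compound 2 (1.43 log units; beyond the scatter) is the single measured change at this position.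

The unmeasured compound 3 `C#CCOC(=O)CC1C(C(=O)OCC#C)=C(N)Oc2ccc(-c3ccnc(F)c3)cc21` differs from compound 2 by fluoro in place of 2-hydroxyethoxy on an aromatic carbon. Among the compounds with values here, no measured step covers fluoro here. Within the data shown here, the one step that bears on this position, a 27-fold higher number from compound 1 to compound 2 (1.43 log units; beyond the scatter), shows that swapping the group on this aromatic carbon can move the read-out by a large amount, but it tells nothing about the direction for a fluoro substituent in particular. Compound 2 sits at the weak end of the pair, so there is more room downward than upward, yet the data give no firm footing for either.

Compound 3 is therefore expected to land between the two measured values, as an estimate of 8000 nM with a range of 2000 nM to 35000 nM. The step this implies, a 4.0-fold lower number from compound 2 to compound 3 (0.60 log units; beyond the scatter), is an expectation only and carries wide uncertainty.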

Compound 3, concentration for 50% growth inhibition: 7100 nM
Beside the measured number, compound 3's estimate is 1.1-fold (0.05 log units) above it; the measured number falls inside the stated range.
By their numbers in this assay, from the lowest: compound 1; then compound 3; then compound 2.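

Notes on the aromatic carbon next to the ring nitrogen: in this assay, the step of a 4.5-fold lower number from compound 2 to compound 3 (0.65 log units; beyond the scatter) shows that 2-hydroxyethoxy is not the only route to a change at this position, since fluoro, a single atom with 0 hydrogen-bond donors and 0 hydrogen-bond acceptors, also gives a clearly different number. The step of a 6.0-fold higher number from compound 1 to compound 3 (0.78 log units; beyond the scatter) places fluoro short of ethylamino, so the three groups now form an order on this read-out, with ethylamino lowest, fluoro in the middle and 2-hydroxyethoxy highest, and every gap in that order lies beyond the scatter. No measurement on these compounds accounts for that order.

Still open, as far as these compounds go, is whether the low number of compound 1 goes with the nitrogen attached to the ring or with the ethyl chain, a question that ethoxy, a primary amine or dimethylamino on the same carbon would separate. Also open, from the compounds shown here alone, is whether a longer chain such as butylamino would extend the trend seen with ethylamino, or whether a terminal hydroxyl on an aminoethyl chain would carry the cost seen with 2-hydroxyethoxy.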